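Swapping the amide substituent in a half-life series

The source may hold more compounds than are shown below. What is called first, only, known or untested is meant among the compounds shown, and "the series" means these compounds.

Of the compounds shown here, two of a shared core have been measured in an ADME assay on microsomes from liver (Mus musculus, strain CD-1) for metabolic stability, read by LC-MS, tested at 2 uM; on this read-out higher numbers stand for a longer-lived compound and lower numbers for a shorter-lived compound. Compound 1 `CN1CCC(NS(=O)(=O)c2ccccc2Nc2cc(-c3ccc4ccn(C)c4c3)c3nccnc3c2)C1` gives 0.667 h in this assay. Compound 2 `Cn1cc(NC(=O)c2ccncc2Nc2cc(-c3ccc4ccn(C)c4c3)c3nccnc3c2)cn1` gives 0.2 h in this assay, the lowest of the two numbers; compound 1 sits higher by a margin beyond the usual scatter. Compound 3 `CC(=O)N1CCC(NC(=O)c2ccncc2Nc2cc(-c3ccc4ccn(C)c4c3)c3nccnc3c2)C1` has not yet been measured. It differs from compound 2 in one place: 1-acetylpyrrolidin-3-yl in place of 1-methyl-1H-pyrazol-4-yl on an amide-type nitrogen. For the measured compounds named here, no two measured compounds differ in only this one place, so the size of this step is unknown. Compound 3 is expected to show a modest rise in half-life over compound 2, a step of a 1.5-fold higher number from compound 2 to compound 3 (0.18 log units; within the scatter) in this assay, not clearly beyond the scatter. Compound 3 is therefore estimated at 0.3 h, within a range of 0.12 h to 0.8 h.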

Compound 3, half-life: 0.667 h
The estimate for compound 3 lay 2.2-fold (0.35 log units) below the measured number; the range from low to high includes it.
By their numbers in this assay, from the lowest: compound 2; then compounds 1 and 3 (each within the scatter of the next).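

For the compounds shown here, putting 1-acetylpyrrolidin-3-yl in place of 1-methyl-1H-pyrazol-4-yl on an amide-type nitrogen gives in this assay a 3.3-fold higher number from compound 2 to compound 3 (0.52 log units; beyond the scatter) and is the first step that can be read at this position. It shows that the group at this one place can by itself shift the half-life beyond the usual scatter while the rest of the molecule stays the same. The change replaces a five-membered aromatic ring with a five-membered non-aromatic ring and also brings in an acetyl group, and no measurement given here explains the step.

The compounds shown leave open which of these two differences matters, the ring or the acetyl group. A 1-methylpyrrolidin-3-yl group, or a pyrrolidin-3-yl group with a free amine, at the same place would help to separate the two.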